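Sulfonamide hydrazides on gastric carcinoma cells: opening notes

The compounds below may be only part of what the source reports. "The series", "measured", "known", "first", "only" and "open" are said of these compounds alone.

Measured so far:
compound 1 `O=C(NNc1ccccc1F)c1ccc(NS(=O)(=O)c2cnc(O)nc2O)cc1` — 16000 nM
compound 2 `Cc1cccc(NNC(=O)c2cccc(NS(=O)(=O)c3cnc(O)nc3O)c2)c1` — > 20000 nM
compound 3 `Cc1cccc(NNC(=O)c2ccccc2NS(=O)(=O)c2cnc(O)nc2O)c1` — > 20000 nM

In a functional assay on SGC-7901 cells (Homo sapiens) for antiproliferative activity, read by MTT assay, with a stated time of 24 h (on this read-out lower numbers stand for stronger inhibition and higher numbers for weaker inhibition), compound 1 gives 16000 nM. For compound 2 the read-out is a limit only, > 20000 nM. For compound 3 the read-out is likewise a limit, > 20000 nM. Compound 3 thus stands at the limit rather than at a number, a situation described by the limit of > 20000 nM in this assay, at which 2 of the 3 values shown sit. Within the data shown here, no step between two measured compounds is available for comparison.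

Compound 4 `O=C(NNC(=O)c1ccccc1NS(=O)(=O)c1cnc(O)nc1O)c1ccc(F)cc1` differs from compound 3 in one place: (4-fluorophenyl)carbonyl in place of 3-methylphenyl on an amine nitrogen. With the series this weak, the expected step in this assay from compound 3 to compound 4 is an at least 1.1-fold lower number from compound 3 to compound 4 (0.04 log units; that floor lies within the scatter), nothing beyond the usual scatter. Compound 4 is estimated at 18000 nM, with a range from 6000 nM to 40000 nM.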

Compound 4, half-maximal inhibitory concentration: > 20000 nM
Compound 4 ended at the assay's limit; the forecaster's own chance of this, stated with the estimate: 50%; at least 1.1-fold (0.04 log units) between middle value and limit.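

In this assay compound 4 gives > 20000 nM, a limit and not a number. Among these compounds, with compound 3 also at a limit, no step between compound 3 and compound 4 can be read. The compounds shown leave open what (4-fluorophenyl)carbonyl in place of 3-methylphenyl does to the read-out.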